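Removing the methoxy group from the core of compound 1

A few compounds are considered here, and "the series" means these few. Any claim that something is new, unique, unknown or untested is made for them only; others in the source may bear on it.

Compound 1 `COc1ccc2nc(NC(=O)CCCCC(=O)NO)sc2c1` and compound 2 `COc1ccc2nc(NC(=O)CCCCCCC(=O)NO)sc2c1` share a core and differ only in the length of the hydroxamic acid chain. In a functional assay on NCI-H460 cells (Homo sapiens) for cytotoxicity (a lower number here means a stronger inhibitor, a higher number a weaker inhibitor), compound 1 gives 21.4 ug/mL and compound 2 gives 1.25 ug/mL; the step of a 17-fold lower number from compound 1 to compound 2 (1.23 log units; beyond the scatter) is large, and compound 1 therefore stands with the highest of the two numbers, its nearest neighbour being compound 2. Compound 3 `O=C(CCCCC(=O)Nc1nc2ccccc2s1)NO` keeps the shorter chain of compound 1 and changes only the core: hydrogen in place of methoxy on an aromatic carbon. Among the measured compounds shown here, no measured step bears directly on this change, since the one step known concerns the chain rather than the aromatic ring, so nothing in the data argues for a shift in this assay beyond the scatter in either direction. Compound 3 is accordingly expected to give about 20 ug/mL, within 7 ug/mL to 60 ug/mL, which means an expected step of a 1.1-fold lower number from compound 1 to compound 3 (0.03 log units; within the scatter).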

Compound 3, half-maximal inhibitory concentration: 14.4 ug/mL
For compound 3 the middle estimate is 1.4-fold (0.14 log units) above the measured one, and the stated range covers the measured number.
By their numbers in this assay, from the lowest: compound 2; then compounds 3 and 1 (each within the scatter of the next).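

In this assay, placing hydrogen in place of methoxy on this aromatic carbon gives a 1.5-fold lower number from compound 1 to compound 3 (0.17 log units; within the scatter), so on the shorter chain the methoxy group can be lost without a step beyond the scatter. Until now the only step available was the chain change, a 17-fold lower number from compound 1 to compound 2 (1.23 log units; beyond the scatter), and the new result shows that, among these compounds, only that chain change has produced a step beyond the scatter. No evidence is available on why the methoxy exchange has so small an effect here.

On these data alone, it remains open whether the same exchange would hold on the longer chain of compound 2, and whether a chlorine atom, an amine or a carboxylic acid on this aromatic carbon would move the number beyond the scatter. A chain longer than that of compound 2 also remains an open question.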